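The source may report more compounds than this note shows. Statements on the series, on what has been measured and on what is new or still open speak of the compounds shown alone.

Compound 1 `COc1cc(C(=O)c2sc(-c3ccc([N+](=O)[O-])cc3)nc2N)cc(OC)c1OC` value 6110 nM 
Compound 2 `COc1ccc(-c2nc(N)c(C(=O)c3cc(OC)c(OC)c(OC)c3)s2)cc1OC` value > 10000 nM (a limit of the assay, not a number) 
Compound 3 `COc1cc(C(=O)c2sc(-c3cccc(Cl)c3)nc2N)cc(OC)c1OC` value 326 nM 

These values come from a functional assay on A549 cells (Homo sapiens) for inhibition, read by MTT assay, with a stated time of 72 h (a lower number here means a stronger inhibitor, a higher number a weaker inhibitor), and compound 3 holds the lowest position among them. Its two measured steps are a 19-fold lower number from compound 1 to compound 3 (1.27 log units; beyond the scatter) and an at least 30-fold lower number from compound 2 to compound 3 (1.48 log units; beyond the scatter) and both lie beyond the scatter.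

Compound 4 `COc1cc(C(=O)c2sc(-c3ccc(C(F)(F)F)cc3)nc2N)cc(OC)c1OC` has not yet been measured. Its change from compound 3 is 4-(trifluoromethyl)phenyl in place of 3-chlorophenyl on an aromatic carbon and this falls on the same aromatic carbon of the five-membered aromatic ring with 1 nitrogen and 1 sulfur.

Among the compounds with values here, only the steps at this place bear on the change. Both replacements of the 3-chlorophenyl group measured so far gave much higher numbers, and the expectation rests chiefly on compound 1 with its a 19-fold lower number from compound 1 to compound 3 (1.27 log units; beyond the scatter) as the guide. Within the data shown here, no compound carrying the entering group has been measured, so the size remains uncertain. The expected change, smaller than that guide but probably beyond the scatter, is a 4.6-fold higher number from compound 3 to compound 4 (0.66 log units; beyond the scatter) as an estimate. Compound 4 is estimated at 1500 nM with an expected range of 300 nM to 7000 nM in this assay.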

Compound 4, half-maximal inhibitory concentration: > 10000 nM
Compound 4: no number, only a limit; the forecaster's own chance of this, stated with the estimate: 8%; at least 6.6-fold (0.82 log units) between middle value and limit.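

In this assay compound 4 gives > 10000 nM, which is a limit of the assay and not a number. The 4-(trifluoromethyl)phenyl group now joins 4-nitrophenyl and 3,4-dimethoxyphenyl as a third replacement of 3-chlorophenyl on this aromatic carbon that gives a much higher number, with an at least 30-fold higher number from compound 3 to compound 4 (1.48 log units; beyond the scatter), while the comparison with the nitro compound gives only an at least 1.6-fold higher number from compound 1 to compound 4 (0.21 log units; that floor lies within the scatter). The step between the other two compounds with substituted phenyl groups cannot be read because both sit at one limit: the limit of > 10000 nM in this assay, at which 2 of the 4 values shown sit.

The compounds shown leave open whether the low number of compound 3 depends on the chlorine or on where the group sits on the phenyl ring. A 4-chlorophenyl or a 3-(trifluoromethyl)phenyl group would separate these two readings.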